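Nitro in place of trifluoromethyl on the shared core

The compounds below may be only part of what the source reports. "The series", "measured", "known", "first", "only" and "open" are said of these compounds alone.

Compound 1 `COc1ccc(-c2nc3cc(C(F)(F)F)ccc3[nH]2)c(OC)c1` has been tested in an ADME assay on BHK cells (Mesocricetus auratus) for cytotoxicity, read by MTT assay, with a stated time of 96 h; a higher number here means that more compound is tolerated, a lower number that less compound is tolerated. In this assay compound 1 gives > 100000 nM, which is a limit of the assay and not a number. Compound 3 `COc1ccc(-c2nc3cc(C(F)(F)F)ccc3[nH]2)cc1` in this assay gives > 100000 nM, again a limit rather than a number. Among the measured compounds shown here, compound 2 `O=C(CN1CCCC1)Nc1ccc(-c2nc3cc(Cl)c(Cl)cc3[nH]2)cc1` in this assay gives 64000 nM, the only value in the set that is a number. The step that the two limits leave unreadable from compound 1 to compound 3 cannot be sized, as both its ends are limits. For the measured compounds named here, compound 1 therefore stands only at a limit, the same point that the limit of > 100000 nM in this assay, at which 2 of the 3 values shown sit, describes for two of the three values, and the one numeric value, that of compound 2, lies within scatter of it.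

Compound 4 `COc1ccc(-c2nc3cc([N+](=O)[O-])ccc3[nH]2)c(OC)c1` differs from compound 1 in one place: nitro in place of trifluoromethyl on an aromatic carbon. Going by the values given here, no measured step concerns a change at this position, so nothing in the set bears on the size of the step; the only measured step is unreadable and touches another position. The expectation is therefore no step beyond the scatter in this assay, with compound 4 expected to remain at or near the limit. For compound 4 the estimate in this assay is 90000 nM, expected between 30000 nM and 250000 nM, which means an expected step of an at least 1.1-fold lower number from compound 1 to compound 4 (0.04 log units; that floor lies within the scatter).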

Compound 4, half-maximal cytotoxic concentration: > 100000 nM
Compound 4 ended at the assay's limit (the forecaster's own chance of this, stated with the estimate: 55%); middle value at least 1.1-fold (0.04 log units) from the limit.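

In this assay compound 4 gives > 100000 nM, a limit of the assay and not a number. Compound 1 also stands only at a limit, so the step between compound 1 and compound 4 cannot be read. The compounds shown leave open what either compound's actual tolerated concentration is, and so whether nitro in place of trifluoromethyl shifts it at all.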